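Replacing 2-Carboxyethyl with Isopropyl in Compound 3

This account rests on a few compounds, and the source may have more. Where it says the series, first, only, none or still open, it means among the compounds named here.

Of the compounds shown here, three have been tested in a physicochemical assay for solubility, in phosphate buffer, at pH 7.4 (on this read-out lower numbers stand for lower solubility and higher numbers for higher solubility), namely compound 1 (`N=C(N)NCCC[C@H](NC(=O)CCCCCNC(=O)NC1CCCCC1)C(=O)O`), compound 2 (`CC(C)[C@H](NC(=O)CCCNC(=O)NC1CCCCC1)C(=O)O`) and compound 3 (`O=C(O)CC[C@H](NC(=O)CNC(=O)NC1CCCCC1)C(=O)O`). Compound 1 gives > 500000 nM, which is a limit and not a number. Compound 3 gives > 500000 nM, again only a limit. Compound 2 carries isopropyl and gives > 500000 nM, also a limit. The three results agree: the limit of > 500000 nM in this assay, at which 3 of the 3 values shown sit.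

Compound 4 (`CC(C)[C@H](NC(=O)CNC(=O)NC1CCCCC1)C(=O)O`) has isopropyl in place of 2-carboxyethyl on a saturated chain carbon bound to an amide-type nitrogen and a carbonyl carbon. Among the measured compounds shown here, no measured pair shows this change alone. In this assay, the expected step of a number no higher from compound 3 to compound 4 (the limit leaves the size open) stays within the scatter, in neither direction. Compound 4 is estimated at 500000 nM, with an expected range from 250000 nM to 600000 nM.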

Compound 4, solubility: > 500000 nM
Compound 4: only a limit was reported (the forecaster's own chance of this, stated with the estimate: 85%); the middle value lies on the limit itself.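

No step can be read from compound 3 to compound 4, because both results are limits and not numbers: the limit of > 500000 nM in this assay, at which 4 of the 4 values shown sit.

The compounds shown leave open how far isopropyl in place of 2-carboxyethyl shifts the result in this assay, or whether it shifts it at all.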